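Amino-naphthyridine series: adding a methyl to compound 2

The source may report more compounds than this note shows. Statements on the series, on what has been measured and on what is new or still open speak of the compounds shown alone.

Measured so far:
compound 1, `Cc1ccc2cc(-c3ccccc3C)nc(N)c2c1`, 200 nM
compound 2, `CN(C)c1cccc2c(N)nc(-c3ccccc3)cc12`, > 10000 nM

In a functional assay on PANC-1 cells (Homo sapiens) for cytotoxicity, read by sulforhodamine B assay (a lower number here means a stronger inhibitor, a higher number a weaker inhibitor), compound 1 gives 200 nM. In this assay compound 2 gives only > 10000 nM, which is a limit of the assay and not a number. Compound 2 therefore stands at the limit of > 10000 nM in this assay, at which 1 of the 2 values shown sits, and no numerical comparison to compound 1 can be drawn from it; compound 1 and compound 2 differ in more than one place, so their two values are simply stated side by side.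

The next compound to follow is compound 3, `Cc1ccccc1-c1cc2c(N(C)C)cccc2c(N)n1`. Compared with compound 2 the change is methyl in place of hydrogen on an aromatic carbon. For the measured compounds named here, no single-point step between measured compounds is available to calibrate this change, so its size in this assay is open; a move toward stronger inhibition is possible, but compound 2 sits at a limit, and a value still at the limit is equally plausible.

Compound 3 is expected to give about 6000 nM in this assay, within 1000 nM to 20000 nM. The step this implies, an at least 1.6-fold lower number from compound 2 to compound 3 (0.22 log units; that floor lies within the scatter), is an estimate only, pending measurement.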

Compound 3, half-maximal inhibitory concentration: > 10000 nM
Compound 3: a limit, no number; the forecaster's own chance of this, stated with the estimate: 50%; middle value at least 1.6-fold (0.22 log units) from the limit.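

In this assay compound 3 gives > 10000 nM, a limit of the assay and not a number. Compound 2 gives > 10000 nM, also a limit, so no step can be read between compound 2 and compound 3: the limit of > 10000 nM in this assay, at which 2 of the 3 values shown sit.

Still open, on these data alone, is whether phenyl to 2-methylphenyl shifts the value at all in this assay for compounds clear of that limit.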